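Naphthyl for Tolyl on a Fused Thiophene Core

This account rests on a few compounds, and the source may have more. Where it says the series, first, only, none or still open, it means among the compounds named here.

Compound 1 `COC1Cc2c(csc2-c2ccccc2)C2(CCN(Cc3ccccc3)CC2)O1` gives 1 nM in an assay on membranes from brain for displacement of a labelled ligand from Sigma non-opioid intracellular receptor 1 (Cavia porcellus), read by scintillation counting, with a stated time of 120 min; on this read-out lower numbers stand for stronger inhibition and higher numbers for weaker inhibition. Compound 2 `COC1Cc2c(csc2-c2ccc(C)cc2)C2(CCN(Cc3ccccc3)CC2)O1` gives 2 nM in this assay; set against compound 1, this gap lies within the scatter. Compound 3 `COC1Cc2c(csc2-c2cccc3ccccc23)C2(CCN(Cc3ccccc3)CC2)O1` carries naphthalen-1-yl in place of 4-methylphenyl on an aromatic carbon. Among the compounds with values here, the only measured step, a 2.0-fold higher number from compound 1 to compound 2 (0.30 log units; within the scatter), changes the same ring by a single methyl and stays within the scatter; no step tests a second fused ring. The step to compound 3 is therefore expected to be small, a 1.5-fold higher number from compound 2 to compound 3 (0.18 log units; within the scatter). Compound 3 is expected at 3 nM in this assay, within a range from 0.8 nM to 12 nM.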

Compound 3, inhibition constant: 5 nM
Compound 3: middle estimate off by 1.7-fold (0.22 log units), on the low side, and the stated range covers the measured number.
By their numbers in this assay, from the lowest: compounds 1 and 2 (each within the scatter of the next); then compound 3.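

In this assay naphthalen-1-yl gives a 2.5-fold higher number from compound 2 to compound 3 (0.40 log units; beyond the scatter) and also a 5.0-fold higher number from compound 1 to compound 3 (0.70 log units; beyond the scatter) on this aromatic carbon next to the ring sulfur. Within the data shown here, the single methyl of compound 2 stayed within the scatter, so this second fused ring is the first change here that the read-out clearly separates. Both steps are modest, so the position accepts the larger group with only a limited loss of binding.

On these data alone, how naphthalen-2-yl, pyridin-3-yl or a phenyl ring bearing an amine would behave at this position remains open. Nothing available explains the shift.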